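The source may report more compounds than this note shows. Statements on the series, on what has been measured and on what is new or still open speak of the compounds shown alone.

In a functional assay on HeLa cells (Homo sapiens) for cytotoxicity, read by sulforhodamine B assay, with a stated time of 72 h (on this read-out lower numbers stand for stronger inhibition and higher numbers for weaker inhibition), three compounds sharing one core have been measured: compound 1 `C=C1C(=O)O[C@@H]2CC(C)=C([C@@H](C)CCCOC(C)=O)[C@@H](OC(=O)CCl)[C@H]12` gives 28500 nM, compound 2 `C=C1C(=O)O[C@@H]2CC(C)=C([C@@H](C)CCCOC(C)=O)[C@@H](OC(=O)CN3CCCCC3)[C@H]12` gives 10300 nM and compound 3 `C=C1C(=O)O[C@@H]2CC(C)=C([C@@H](C)CCCOC(C)=O)[C@@H](OC(=O)COc3cccc4cccnc34)[C@H]12` gives 8940 nM. Compound 3 thus sits level with compound 2, and both stand under compound 1. Compound 4 `C=C1C(=O)O[C@@H]2CC(C)=C([C@@H](C)CCCOC(C)=O)[C@@H](OC(=O)c3cccc(F)c3)[C@H]12` carries 3-fluorophenyl in place of ((quinolin-8-yl)oxy)methyl on a carbonyl carbon. The nearest evidence comes from changes on a saturated chain carbon bound to a carbonyl carbon, where a 2.8-fold lower number from compound 1 to compound 2 (0.44 log units; beyond the scatter) and a 3.2-fold lower number from compound 1 to compound 3 (0.50 log units; beyond the scatter) are modest. Within the data shown here, with a 1.2-fold lower number from compound 2 to compound 3 (0.06 log units; within the scatter) as the closest guide, no step beyond the scatter is expected in this assay, though no measured step tests 3-fluorophenyl on a carbonyl carbon. The expected change is a 1.3-fold higher number from compound 3 to compound 4 (0.13 log units; within the scatter). For compound 4 the estimate is 12000 nM, with an expected range of 4500 nM to 30000 nM.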

Compound 4, half-maximal inhibitory concentration: 11800 nM
For compound 4 the middle estimate is 1.0-fold (0.01 log units) above the measured one, within the range that was stated.
By their numbers in this assay, from the lowest: compounds 3, 2 and 4 (each within the scatter of the next); then compound 1.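

In this assay, 3-fluorophenyl on this carbonyl carbon, with one carbon-only aromatic ring and no hydrogen-bond acceptors, matches ((quinolin-8-yl)oxy)methyl, with a 1.3-fold higher number from compound 3 to compound 4 (0.12 log units; within the scatter). The same holds against (piperidin-1-yl)methyl, with a 1.1-fold higher number from compound 2 to compound 4 (0.06 log units; within the scatter), while the replacement of chloromethyl gives a 2.4-fold lower number from compound 1 to compound 4 (0.38 log units; beyond the scatter), so among these compounds neither a ring nitrogen nor a saturated chain carbon on the carbonyl carbon is needed to reach this level. Nothing measured here accounts for this result.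

Going by these compounds, how plain phenyl compares with 3-fluorophenyl at this carbonyl carbon remains open. So does the effect of a carboxylic acid on that ring or of a longer chain here.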